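The compounds below may be only part of what the source reports. "The series", "measured", "known", "first", "only" and "open" are said of these compounds alone.

Measured so far in an assay on HL-60 cells for inhibition of P-selectin (Homo sapiens); on this read-out higher numbers stand for weaker inhibition and lower numbers for stronger inhibition:

- Compound 1, `O=C(O)CCCNC(=O)[C@]1(O)C[C@@H](O)[C@@H](O)[C@H](O)C1`: 40000000 nM
- Compound 2, `O=C(O)CCCCCNC(=O)[C@]1(O)C[C@@H](O)[C@@H](O)[C@H](O)C1`: a limit, > 50000000 nM
- Compound 3, `O=C(O)CC[C@H](NC(=O)[C@]1(O)C[C@@H](O)[C@@H](O)[C@H](O)C1)C(=O)O`: 21000000 nM

Of the two numbers, that of compound 3 is the lowest, although the step of a 1.9-fold lower number from compound 1 to compound 3 (0.28 log units; within the scatter) sits within the scatter. For compound 2 this assay gives only a limit, > 50000000 nM; this is the limit of > 50000000 nM in this assay, at which 1 of the 3 values shown sits.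

Compound 4, `CCC(C)[C@H](NC(=O)[C@]1(O)C[C@@H](O)[C@@H](O)[C@H](O)C1)C(=O)O`, is the next compound to be measured. Its change from compound 3 is sec-butyl in place of 2-carboxyethyl on a saturated chain carbon bound to an amide-type nitrogen and a carbonyl carbon. Going by the values given here, two measured steps bear on it. The step of a 1.9-fold lower number from compound 1 to compound 3 (0.28 log units; within the scatter) shows what putting a carboxy on this chain carbon did, and compound 4 takes the acid away again while adding sec-butyl. The step of an at least 1.2-fold higher number from compound 1 to compound 2 (0.09 log units; that floor lies within the scatter) shows that moving the acid further along a chain reached the limit of this assay. Neither step is beyond the scatter, so a small shift toward a higher number is expected, with a real chance that only a limit is returned. The expected step is a 1.9-fold higher number from compound 3 to compound 4 (0.28 log units; within the scatter). Compound 4 is therefore estimated at 40000000 nM, with a range from 15000000 nM to 100000000 nM.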

Compound 4, half-maximal inhibitory concentration: 19000000 nM
Compound 4: the middle estimate sits 2.1-fold (0.32 log units) above what was measured, and the stated range covers the measured number.
By their numbers in this assay, from the lowest: compounds 4, 3 and 1 (each within the scatter of the next, the first and the last beyond it). At a limit, above all of these: compound 2.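

In this assay, the exchange on the saturated chain carbon bound to an amide-type nitrogen and a carbonyl carbon gives a 1.1-fold lower number from compound 3 to compound 4 (0.04 log units; within the scatter). At this place, then, 2-carboxyethyl, with its hydrogen-bond donor and acceptor, can give way to sec-butyl, which has neither, without a step beyond the scatter, so the second carboxylic acid of compound 3 is not required to keep the number at this level. Nothing measured here on either group accounts for this result.

As far as these compounds go, whether an amine or a phenyl group on this chain carbon would move the number beyond the scatter remains open. So does the part played by the carboxy on this same carbon, which compound 3 and compound 4 share.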